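This account rests on a few compounds, and the source may have more. Where it says the series, first, only, none or still open, it means among the compounds named here.

Compound 2 `O=C(CSc1snnc1-c1ccccc1)Nc1ccccc1[N+](=O)[O-]` was tested in an ADME assay on MT4 cells (Homo sapiens) for cytotoxicity (a higher number here means that more compound is tolerated, a lower number that less compound is tolerated), and gives only a limit there, >= 246000 nM, not a number. Compound 1 `COc1ccc(-c2nnsc2SCC(=O)Nc2ccccc2Cl)cc1` likewise reaches a limit in this assay, namely > 318000 nM. Compound 3 `COC(=O)c1ccc(NC(=O)CSc2snnc2-c2ccc(OC)cc2)c(Br)c1` gives a number in this assay, 195000 nM. Compound 2 thus stands at one of the two limits among the three values shown. The third value, that of compound 3, lies in the same region. The untested compound 4 `O=C(CSc1snnc1-c1ccc(F)cc1F)Nc1ccccc1[N+](=O)[O-]` differs from compound 2 in one place: 2,4-difluorophenyl in place of phenyl on an aromatic carbon. Among the compounds with values here, no measured step of this kind exists here, so this change is expected to give a step that the limit leaves unreadable from compound 2 to compound 4, nothing beyond the usual scatter. For compound 4 the expected value in this assay is 250000 nM, within a range from 120000 nM to 500000 nM.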

Compound 4, half-maximal cytotoxic concentration: 165000 nM
Beside the measured number, compound 4's estimate is 1.5-fold (0.18 log units) above it; the measured number falls inside the stated range.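

Within the data shown here, the swap of phenyl for 2,4-difluorophenyl on the five-membered aromatic ring gives the first step at this position in this assay: an at least 1.4-fold lower number from compound 2 to compound 4 (0.17 log units; that floor lies within the scatter). This step is only a floor because compound 2 stands at a limit: the limit of >= 246000 nM in this assay, at which 1 of the 4 values shown sits.

Compound 4 gives a real number, so the added fluorines leave the compound in the same region as the other values, with no change shown beyond the scatter. On these data alone, whether a single fluorine, an amine or a carboxylic acid on that phenyl ring would move the number further remains open.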